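Swapping trifluoromethyl for butyl on the anilide

The source may hold more compounds than are shown below. What is called first, only, known or untested is meant among the compounds shown, and "the series" means these compounds.

Compound 1 (`COC(=O)[C@]1(O)C[C@@H](O)[C@@H](O)[C@H](OC(=O)/C=C/c2ccc(O)c(O)c2)C1`), a limit (> 40000 nM)
Compound 2 (`O=C(/C=C/c1ccc(O)c(O)c1)Nc1ccc(C(F)(F)F)cc1`), a number (1400 nM)

For the measured compounds named here, in a functional assay on B16 cells (Mus musculus) for inhibition (a lower number here means a stronger inhibitor, a higher number a weaker inhibitor), compound 2 gives the only actual number (1400 nM) among the values so far. Compound 1 stands at a limit of the assay (> 40000 nM) and not at a number. Compound 3 (`CCCCc1ccc(NC(=O)/C=C/c2ccc(O)c(O)c2)cc1`) has butyl in place of trifluoromethyl on an aromatic carbon, para to a large group (butyl in place of trifluoromethyl on an aromatic carbon). Going by the values given here, no measured step shows what such a swap does in this assay, so no change beyond the scatter is expected, in either direction (a 1.2-fold lower number from compound 2 to compound 3 (0.07 log units; within the scatter)). For compound 3 the estimated value is 1200 nM (expected range 300 nM to 5000 nM).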

Compound 3, half-maximal inhibitory concentration: 1200 nM
For compound 3 middle estimate and measured number coincide at the digits printed; the range from low to high includes it.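

Butyl in place of trifluoromethyl on an aromatic carbon, para to a large group, gives in this assay a 1.2-fold lower number from compound 2 to compound 3 (0.07 log units; within the scatter). For the compounds shown here, this is the first step that can be read at this place, and it shows that these two groups, each of four heavy atoms, cannot be told apart here. Nothing shown gives a reason for this outcome.

On these data alone, what an amine, a carboxylic acid or a chain longer than butyl would do at this place stays open. So does the effect of moving butyl to another carbon of the ring.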